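The source may report more compounds than this note shows. Statements on the series, on what has been measured and on what is new or still open speak of the compounds shown alone.

Values in a functional assay on MCF7 cells (Homo sapiens) for antiproliferative activity, read by sulforhodamine B assay, with a stated time of 72 h; a higher number here means a weaker inhibitor, a lower number a stronger inhibitor:
- Compound 1 `COc1ccc(NC(=O)Cn2nc(Cc3ccccc3)c3ccccc3c2=O)cc1`: 62000 nM
- Compound 2 `O=C(Cn1nc(Cc2ccccc2)c2ccccc2c1=O)Nc1ccc(F)cc1`: 30000 nM

Of these two compounds, compound 2 has the lower number, 30000 nM, which makes it the stronger inhibitor of the pair. The next compound, compound 3 `O=C(Cn1nc(Cc2ccccc2)c2ccccc2c1=O)Nc1ccccc1Cl`, keeps the shared core but carries a different group: 2-chlorophenyl in place of 4-fluorophenyl on an amide-type nitrogen. Put simply, 2-chlorophenyl stands in place of 4-fluorophenyl on an amide-type nitrogen.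

Among the measured compounds shown here, only one measured step bears on this change: a 2.1-fold lower number from compound 1 to compound 2 (0.32 log units; beyond the scatter). That modest step also swapped a group on this aromatic ring, fluoro in place of methoxy. For the measured compounds named here, no measured compound carries chlorine, so the direction in this assay remains open, and a step no larger than that one seems likely. The estimated change is small: a 1.2-fold higher number from compound 2 to compound 3 (0.07 log units; within the scatter). For compound 3 the expected value is 35000 nM, with an expected range of 14000 nM to 85000 nM.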

Compound 3, half-maximal inhibitory concentration: 89000 nM
For compound 3 the middle estimate is 2.5-fold (0.41 log units) below the measured one; the whole stated range lies below it.
By their numbers in this assay, from the lowest: compound 2; then compounds 1 and 3 (each within the scatter of the next).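

In this assay, this position on the amide-type nitrogen now shows that a swap can also raise the number: 2-chlorophenyl in place of 4-fluorophenyl gives a 3.0-fold higher number from compound 2 to compound 3 (0.47 log units; beyond the scatter), and 4-fluorophenyl keeps the lowest number of the three. Replacing 4-methoxyphenyl with 2-chlorophenyl gives a 1.4-fold higher number from compound 1 to compound 3 (0.16 log units; within the scatter), so these two groups cannot be told apart here, and only 4-fluorophenyl stands clear of the others. Nothing available explains these differences.

This change replaces the halogen and alters where it sits in a single step, so the two effects stay tangled until 4-chlorophenyl or 2-fluorophenyl can be compared. Also open, as far as these compounds go, is how a plain phenyl group, or a phenyl group carrying an amine or a carboxylic acid, would behave at this position.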